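Working notes: from compound 3 to compound 4

A few compounds are considered here, and "the series" means these few. Any claim that something is new, unique, unknown or untested is made for them only; others in the source may bear on it.

Measured so far in an assay on cells for agonist activity at ecdysone receptor (Bombyx mori), read by a luciferase reporter, with a stated time of 24 h; a higher number here means that more compound is needed for the effect, a lower number that less compound is needed:
compound 1, `CC(C)(C)N(NC(=O)c1ccccc1)C(=O)c1ccccc1Cl`, gives 75.9 nM
compound 2, `CC(C)(C)N(NC(=O)c1ccccc1I)C(=O)c1ccccc1Cl`, gives 1290 nM
compound 3, `Cc1cccc(C(=O)NN(C(=O)c2ccccc2Cl)C(C)(C)C)c1`, gives 603 nM

Compound 3 stands second highest of the three numbers in this assay; its nearest neighbour is compound 2, reached by a 2.1-fold lower number from compound 2 to compound 3 (0.33 log units; beyond the scatter), and the furthest is compound 1, the gap being a 7.9-fold higher number from compound 1 to compound 3 (0.90 log units; beyond the scatter).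

Compound 4, `Cc1ccc(C(=O)NN(C(=O)c2ccccc2Cl)C(C)(C)C)c(C)c1`, is not yet measured. The change from compound 3 is 2,4-dimethylphenyl in place of 3-methylphenyl on a carbonyl carbon.

Within the data shown here, two measured steps bear on it, both of them substitutions on the same phenyl that carries no substituent in compound 1: a 17-fold higher number from compound 1 to compound 2 (1.23 log units; beyond the scatter) and a 7.9-fold higher number from compound 1 to compound 3 (0.90 log units; beyond the scatter). Each added group on that ring raised the number beyond the scatter, the iodo step being the larger. Among the measured compounds shown here, compound 4 adds a second methyl and moves the first; no measured pair shows either effect directly, so the direction is taken from the trend and the size kept modest. A further rise is therefore expected, a 2.5-fold higher number from compound 3 to compound 4 (0.40 log units; beyond the scatter), in this assay.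

For compound 4 the expected value is 1500 nM, with a range from 500 nM to 5000 nM.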

Compound 4, half-maximal effective concentration: 162 nM
Compound 4: the middle estimate sits 9.3-fold (0.97 log units) above what was measured, and the stated range ends above it.
By their numbers in this assay, from the lowest: compound 1; then compound 4; then compound 3; then compound 2.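

In this assay, substitution on the phenyl on the carbonyl carbon no longer raises the number in a single direction: with 2,4-dimethylphenyl in place of 3-methylphenyl, the result is a 3.7-fold lower number from compound 3 to compound 4 (0.57 log units; beyond the scatter) and the earlier rise with each added group does not hold. The pattern of the substituent therefore matters more than its mere presence, as an 8.0-fold lower number from compound 2 to compound 4 (0.90 log units; beyond the scatter) also shows, although unsubstituted phenyl still holds the lowest number, with a 2.1-fold higher number from compound 1 to compound 4 (0.33 log units; beyond the scatter) on this ring. Nothing available gives a reason for this reversal.

Among these compounds, open is which of the two methyl groups of 2,4-dimethylphenyl accounts for the lower number, or whether only the pair together does so. Also open, from the compounds shown here alone, is how this ring would read with a methoxy group, an amine or a carboxylic acid in place of methyl.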